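This account rests on a few compounds, and the source may have more. Where it says the series, first, only, none or still open, it means among the compounds named here.

Measured in an ADME assay on microsomes from liver (Homo sapiens) for metabolic stability, read by LC-MS, using NADPH, with stated times of 5 min and 30 min, tested at 1 uM; on this read-out lower numbers stand for slow clearance and higher numbers for fast clearance:

- Compound 1 `O=C(Nc1ccccc1)c1cnc(NCc2c(F)ccc3c2CCO3)n2cnnc12`: 14 mL.min-1.g-1
- Compound 2 `Cc1ncccc1-c1cnc(NCc2c(F)ccc3c2CCO3)c2nn(CC#N)c(=O)n12`: 151 mL.min-1.g-1
- Compound 3 `Cc1nc(CN(C)C)ccc1-c1cnc(NCc2c(F)ccc3c2CCO3)c2cn[nH]c(=O)c12`: 13 mL.min-1.g-1

Compound 1 at 14 mL.min-1.g-1 and compound 3 at 13 mL.min-1.g-1 cannot be told apart, since their gap lies within the usual scatter of repeated measurements. Compound 2 at 151 mL.min-1.g-1 stands far higher than both, well beyond that scatter. Compound 1 therefore belongs to the low-clearance end of this small set.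

The next compound to consider is compound 4 `CC1(C)CC(=O)N(c2cnc(NCc3c(F)ccc4c3CCO4)n3cnnc23)C1`. It keeps the core of compound 1 and carries 4,4-dimethyl-2-oxopyrrolidin-1-yl in place of phenylcarbamoyl on an aromatic carbon. An aromatic ring of carbon only leaves, and a non-aromatic ring enters.

Within the data shown here, no measured pair differs by one change alone, so the data offer no direct guide to the effect of this swap. The best expectation is a small rise, probably within the scatter. Compound 2 at 151 mL.min-1.g-1 shows that much higher numbers do occur among these compounds, so the upper end of the range is left wide.

The expected step is a 1.6-fold higher number from compound 1 to compound 4 (0.20 log units; within the scatter). In this assay, the estimate for compound 4 is 22 mL.min-1.g-1, with an expected range of 9 mL.min-1.g-1 to 60 mL.min-1.g-1.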

Compound 4, intrinsic clearance in microsomes: 16 mL.min-1.g-1
The estimate for compound 4 lay 1.4-fold (0.14 log units) above the measured number; the measured number falls inside the stated range.
By their numbers in this assay, from the lowest: compounds 3, 1 and 4 (each within the scatter of the next); then compound 2.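

Among these compounds, this is the first pair in the set that differs in one place only, so the group on this aromatic carbon can now be judged on its own: in this assay, putting 4,4-dimethyl-2-oxopyrrolidin-1-yl in place of phenylcarbamoyl gives a 1.1-fold higher number from compound 1 to compound 4 (0.06 log units; within the scatter) and leaves the two compounds impossible to tell apart. The change is not a small one on paper, as a six-membered aromatic ring of carbon only gives way to a five-membered non-aromatic ring, and the count of hydrogen-bond donors goes from 1 to 0, yet on the core of compound 1 this read-out does not separate the two groups. Nothing measured here explains why these two groups read alike.

Still open, going by these compounds, is how other kinds of group would read at this position, for example a primary amine, a carboxylic acid or a longer alkyl chain. Also open, on these data alone, is whether this same swap would read alike on a different core, such as that of compound 2, since a single pair speaks only for the core of compound 1.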